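The source may hold more compounds than are shown below. What is called first, only, known or untested is meant among the compounds shown, and "the series" means these compounds.

Among the measured compounds shown here, in a functional assay on MCF7 cells (Homo sapiens) for antiproliferative activity, read by MTT assay, with stated times of 24 h and 72 h (on this read-out lower numbers stand for stronger inhibition and higher numbers for weaker inhibition), compound 2 (`COc1ccc([C@@H]2[C@H](Oc3ccccc3)C(=O)N2c2cc(OC)c(OC)c(OC)c2)cc1NC(=O)CN`) gives 6500 nM and compound 1 (`COc1ccc([C@@H]2[C@H](Oc3ccccc3)C(=O)N2c2cc(OC)c(OC)c(OC)c2)cc1NC(=O)C(C)N`) gives 9200 nM, so compound 2 stands level with its only neighbour. Compound 3 (`COc1ccc([C@@H]2[C@H](Oc3ccccc3)C(=O)N2c2cc(OC)c(OC)c(OC)c2)cc1OP(=O)(O)O`) follows from compound 2 through (a group of 5 heavy atoms (4 oxygen, 1 phosphorus; no ring) in place of a group of 5 heavy atoms (2 carbon, 2 nitrogen, 1 oxygen; no ring), on an aromatic carbon), on an aromatic carbon, ortho to a methoxy group. For the measured compounds named here, the one measured step, a 1.4-fold lower number from compound 1 to compound 2 (0.15 log units; within the scatter), only changes a methyl to hydrogen on the side chain, so it says little about this exchange. Going by the values given here, no measured step covers the exchange itself. The expected change, towards stronger inhibition and held loosely, is an 8.1-fold lower number from compound 2 to compound 3 (0.91 log units; beyond the scatter). For compound 3 the estimate is 800 nM, with an expected range of 50 nM to 8000 nM.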

Compound 3, half-maximal inhibitory concentration: 42000 nM
Compound 3: middle estimate off by 53-fold (1.72 log units), on the low side; the measured number lies above the stated range.
By their numbers in this assay, from the lowest: compounds 2 and 1 (each within the scatter of the next); then compound 3.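

In this assay the position ortho to a methoxy group does not tolerate every group of this size: the group of 4 oxygen and 1 phosphorus gives weaker inhibition, with a 6.5-fold higher number from compound 2 to compound 3 (0.81 log units; beyond the scatter) and a 4.6-fold higher number from compound 1 to compound 3 (0.66 log units; beyond the scatter) as the two readings. The leaving and entering groups have matching counts of heavy atoms, donors and acceptors, so those counts alone do not preserve activity here. Nothing available explains this loss.

Still open, as far as these compounds go, is how a free amine, a hydroxyl or a carboxylic acid would read at this position. A longer chain on the amide is also untested in the compounds shown.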